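One number, one swap: nitro to chloro

The source may hold more compounds than are shown below. What is called first, only, known or untested is meant among the compounds shown, and "the series" means these compounds.

Measured so far:
Compound 1 `Cc1ccc(C)n1-c1ccc(C(=O)N/N=C/c2ccccc2)cc1`: "not determined" (no result reported)
Compound 2 `O=C(NNC(=O)c1ccc([N+](=O)[O-])cc1)c1ccc(-n2cccc2)cc1`: 190000 nM
Compound 3 `C/C(=N/NC(=O)c1ccc(-n2c(C)ccc2C)cc1)c1ccc(N)cc1`: "not determined" (no result reported)

Among the measured compounds shown here, compound 2 is the only compound with a number in an ADME assay on Vero cells (Chlorocebus sabaeus) for cytotoxicity, read by MTT assay, with a stated time of 72 h (on this read-out lower numbers stand for stronger inhibition and higher numbers for weaker inhibition), and stands at 190000 nM on that scale. Compound 1 and compound 3 have no reported result, so compound 2 cannot be ranked against either of them.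

The next compound to be measured is compound 4 `O=C(NNC(=O)c1ccc(-n2cccc2)cc1)c1ccc(Cl)cc1`. It differs from compound 2 in one place, with chloro in place of nitro on an aromatic carbon. For the measured compounds named here, the data contain no pair of measured compounds that differ in one place, so they give no size for a swap of this kind. With compound 2 at 190000 nM as the sole reference point, no move beyond the scatter is expected, and neither direction can be favoured with any confidence. The estimated change, a 1.2-fold lower number from compound 2 to compound 4 (0.07 log units; within the scatter), is expected to remain within the usual scatter of repeated measurements. In this assay compound 4 is estimated at 160000 nM with an expected range from 60000 nM to 400000 nM on this read-out.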

Compound 4, half-maximal inhibitory concentration: 179000 nM
Compound 4: the middle estimate sits 1.1-fold (0.05 log units) below what was measured, and the stated range covers the measured number.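

In this assay, among the compounds shown here, the first step that can be read is a 1.1-fold lower number from compound 2 to compound 4 (0.03 log units; within the scatter), where chloro takes the place of nitro on an aromatic carbon, para to a large group. At this position, nitro, with 3 heavy atoms and 2 hydrogen-bond acceptors, can give way to chloro, with 1 heavy atom and 0 hydrogen-bond acceptors, while the read-out stays within the usual scatter of repeated measurements, so this assay does not tell compound 2 and compound 4 apart. Nothing in the data offers a reason for this outcome.

On these data alone, this is a single swap at a single position, so it remains open whether a different group there, such as an amine, a carboxylic acid or a longer chain, would move the number beyond the scatter. As far as these compounds go, it also remains open whether the same swap would behave alike on another core, such as that of compound 1 or compound 3, neither of which has a reported result to compare with.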